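Adding a bromine to an inactive anilino compound

The source may report more compounds than this note shows. Statements on the series, on what has been measured and on what is new or still open speak of the compounds shown alone.

Compound 1 `CC(C)CNc1nc(/C=C/c2ccccc2)nc2ccsc12`: in a functional assay on L02 cells (Homo sapiens) for inhibition, read by Griess assay, with stated times of 1 h and 24 h (on this read-out higher numbers stand for weaker inhibition and lower numbers for stronger inhibition), compound 1 gives > 1000000 nM.
Compound 2 `C(=C/c1nc(Nc2ccccc2)c2sccc2n1)\c1ccccc1`: in this assay compound 2 gives > 1000000 nM.

For compound 1 that value is a limit of the assay, not a number. For compound 2 the value is likewise a limit of the assay, not a number. The change from compound 1 to compound 2, phenyl in place of isobutyl on a nitrogen on an aromatic ring, therefore gives a step that the two limits leave unreadable from compound 1 to compound 2. Both compounds sit at the limit of > 1000000 nM in this assay, at which 2 of the 2 values shown sit, so no readable step exists between them.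

Compound 3 `Brc1cccc(Nc2nc(/C=C/c3ccccc3)nc3ccsc23)c1` differs from compound 2 by bromo in place of hydrogen on an aromatic carbon, placed on an aromatic carbon of a six-membered aromatic ring of carbon only, meta to a large group. For the measured compounds named here, no measured step bears on this change, and the only measured step in this assay is itself unreadable. For compound 3 the expectation is that the value remains at the limit, so the estimate is 1000000 nM, within 300000 nM to 3000000 nM. The step expected from compound 2 to compound 3 is a number no higher from compound 2 to compound 3 (the limit leaves the size open), most likely again reported only as a limit.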

Compound 3, half-maximal inhibitory concentration: > 1000000 nM
Compound 3 gave a limit, no number; the forecaster's own chance of this, stated with the estimate: 80%; the middle value lies on the limit itself.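

Compound 1, compound 2 and compound 3 all give only a limit in this assay, not a number, so no step among them can be read: the limit of > 1000000 nM in this assay, at which 3 of the 3 values shown sit.

The compounds shown leave open how strongly, if at all, any of the three inhibits, and what bromo in place of hydrogen does to that inhibition.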